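Trimming an Ethoxy Group from a Piperazine Amide

The compounds below may be only part of what the source reports. "The series", "measured", "known", "first", "only" and "open" are said of these compounds alone.

Of the compounds shown here, two with the same shared core have been tested in a functional assay on HL-60 cells (Homo sapiens) for inhibition, read by MTT assay, with a stated time of 72 h; on this read-out higher numbers stand for weaker inhibition and lower numbers for stronger inhibition. Compound 1 `O=C(c1oc(C(F)(F)F)nc1-c1cccc(Cl)c1)N1CCN(c2cccc(Cl)c2)CC1` carries a trifluoromethyl group and two chlorine-bearing rings; in this assay compound 1 is reported as "not active" (no number reported), so no number is available for it. Going by the values given here, compound 2 `CCOc1cccc(N2CCN(C(=O)c3oc(C)nc3-c3ccccc3)CC2)c1` replaces those groups with a methyl, an unsubstituted phenyl and an ethoxyphenyl; in this assay compound 2 gives 151 nM, the only number so far, so nothing can be said about where it stands relative to other measured compounds.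

Compound 3 `Cc1nc(-c2ccccc2)c(C(=O)N2CCN(c3ccccc3)CC2)o1` differs from compound 2 in one place: hydrogen in place of ethoxy on an aromatic carbon. The ethoxy group is removed, leaving a plain phenyl ring in the words of the difference: 3-ethoxyphenyl to phenyl.

Among the compounds with values here, no measured pair shows what this change does here. Losing a hydrogen-bond acceptor and three heavy atoms might cost some potency, so the step from compound 2 to compound 3 is expected to be a modest move toward weaker inhibition, a 2.3-fold higher number from compound 2 to compound 3 (0.37 log units; beyond the scatter), possibly no larger than the scatter. Compound 3 is estimated at 350 nM, within a range of 120 nM to 1500 nM.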

Compound 3, half-maximal inhibitory concentration: 39.1 nM
Compound 3: middle estimate off by 9.0-fold (0.95 log units), on the high side; measured number below the stated range.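

Taking the ethoxy group off the ring in this assay gives a 3.9-fold lower number from compound 2 to compound 3 (0.59 log units; beyond the scatter) and so improves inhibition, a move that runs in the direction of stronger activity even though the change is small in structural terms. This shows that, in this pair, the ethoxy group on this aromatic carbon is not needed for activity: the plain phenyl ring, without its 3 heavy atoms and 1 hydrogen-bond acceptor, does better than the 3-ethoxyphenyl ring. Nothing shown here explains why the number falls.

One pair cannot tell whether any group at this place lowers inhibition or whether the result is specific to ethoxy, so a smaller methoxy group, a longer propoxy chain, a fluorine atom or an amine at the same carbon could each give a different answer. As far as these compounds go, it also remains open whether removing ethoxy would have the same effect with other groups on the shared core, such as the trifluoromethyl and chlorine-bearing rings of compound 1, which differs from compound 3 in more than one place.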